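This account rests on a few compounds, and the source may have more. Where it says the series, first, only, none or still open, it means among the compounds named here.

Compound 2 `Oc1ccc(-c2cc(-c3cccc(C(F)(F)F)c3)cc(-c3ccccc3O)n2)cc1` was examined in a functional assay on HeLa cells (Homo sapiens) for inhibition (on this read-out lower numbers stand for stronger inhibition and higher numbers for weaker inhibition), alongside compound 1 `Oc1ccc(-c2cc(-c3ccccc3F)cc(-c3ccc(O)cc3)n2)cc1`. In this assay compound 2 reaches only the limit of the measurement, > 50000 nM, and no number is obtained. Compound 1 likewise gives a limit in this assay, > 50000 nM. Both values therefore sit at the same point, (the limit of > 50000 nM in this assay, at which 2 of the 2 values shown sit), so compound 2 stands nowhere above or below its companion; the two are simply unresolved at the edge of the assay.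

From compound 2 the next structure, compound 3 `Oc1ccc(-c2cc(-c3cccc(C(F)(F)F)c3)cc(-c3ccc(O)cc3)n2)cc1`, is reached through a rearrangement (4-hydroxyphenyl in place of 2-hydroxyphenyl on an aromatic carbon). Compound 1, which already carries two 4-hydroxyphenyl groups, remains at the limit, and compound 2 does as well, so no direction of travel can be read from the measured pairs. The expected step that the limit leaves unreadable from compound 2 to compound 3 is accordingly none beyond the scatter, with a good chance that compound 3 also returns only a limit. Compound 3 is estimated at 60000 nM in this assay, within 20000 nM to 200000 nM.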

Compound 3, half-maximal inhibitory concentration: > 50000 nM
Compound 3: only a limit was reported; the forecaster's own chance of this, stated with the estimate: 85%; the middle value does not contradict the limit.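

Compound 3 also gives only a limit in this assay, so no step can be read from compound 2 to compound 3 or from compound 1 to compound 3: the limit of > 50000 nM in this assay, at which 3 of the 3 values shown sit.

The compounds shown leave open whether exchanging any of these groups changes inhibition in this assay, since none of the three has yielded a number.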